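From ethoxycarbonyl to hydroxymethyl on the shared core

The source may report more compounds than this note shows. Statements on the series, on what has been measured and on what is new or still open speak of the compounds shown alone.

Values measured in a functional assay on SW480 cells (Homo sapiens) for cytotoxicity, read by MTT assay, with a stated time of 48 h; on this read-out higher numbers stand for weaker inhibition and lower numbers for stronger inhibition:
Compound 1 `COc1cc([C@H]2C[C@@]2(CO)C(=O)Nc2ccccc2)cc(OC)c1OC`: > 100000 nM (a limit)
Compound 2 `COc1cc([C@H]2C[C@]2(CO)C(=O)NCc2ccc(C)cc2)cc(OC)c1OC`: 94000 nM
Compound 3 `CCOC(=O)[C@@]1(C(=O)NCc2ccc(C)cc2)C[C@@H]1c1cc(OC)c(OC)c(OC)c1`: > 100000 nM (a limit)

Compound 3 has no number in this assay, only a limit, > 100000 nM. Among the compounds with values here, compound 1 is the one other compound reported only as a limit. The set as a whole is marked by the limit of > 100000 nM in this assay, at which 2 of the 3 values shown sit.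

Compound 4 `COc1cc([C@H]2C[C@@]2(CO)C(=O)NCc2ccc(C)cc2)cc(OC)c1OC` has not yet been measured. It differs from compound 3 by one change, hydroxymethyl in place of ethoxycarbonyl on a saturated ring carbon. Within the data shown here, no measured pair shows this change on its own, so any expectation has little to rest on. Compound 1 also carries hydroxymethyl and gives only a limit. Among the measured compounds shown here, compound 2 also carries hydroxymethyl and gives 94000 nM, the one true number so far, and the expectation leans on that value. In this assay no shift beyond the usual scatter is expected, and the expected step is an at least 1.1-fold lower number from compound 3 to compound 4 (0.04 log units; that floor lies within the scatter). For compound 4 the estimate is 90000 nM, with an expected range from 40000 nM to 160000 nM.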

Compound 4, half-maximal inhibitory concentration: > 100000 nM
Compound 4 ended at the assay's limit; the forecaster's own chance of this, stated with the estimate: 55%; middle value at least 1.1-fold (0.04 log units) away from the limit.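

In this assay, putting hydroxymethyl in place of ethoxycarbonyl on this saturated ring carbon did not yield a true number, since compound 4 is reported only as a limit; the steps reaching it from compound 3 and from compound 1 cannot be read, as both ends of each are limits. The one readable step, an at least 1.0-fold higher number from compound 2 to compound 4 (0.02 log units; that floor lies within the scatter), concerns the configuration drawn at a stereocentre on a saturated ring carbon rather than the group itself, and it is the first comparison of this kind in the set: the fact that compounds 2 and 4 differ only in the configuration as drawn. Its printed floor lies within the usual scatter, so it does not establish that this configuration matters, and most of the series remains at the limit: the limit of > 100000 nM in this assay, at which 3 of the 4 values shown sit.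

The compounds shown leave open whether a carboxylic acid or an aminomethyl group on this saturated ring carbon would give a true number in this assay. They also leave open how the two configurations at this stereocentre compare when ethoxycarbonyl takes the place of hydroxymethyl.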